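The source may report more compounds than this note shows. Statements on the series, on what has been measured and on what is new or still open speak of the compounds shown alone.

For the measured compounds named here, in a functional assay on L1210 cells (Mus musculus) (a higher number here means a weaker inhibitor, a lower number a stronger inhibitor), compound 1 `CCCNC(=O)Nc1ccc(C(C)C)cc1` gives 14000 nM, the higher of the two numbers so far, while compound 2 `CCCNC(=O)Nc1ccc(C(C)(C)C)cc1` gives 5400 nM. Compound 3 `CNC(=O)Nc1ccc(C(C)C)cc1` keeps the core of compound 1 with one change: hydrogen in place of ethyl on a saturated chain carbon bound to an amide-type nitrogen. Going by the values given here, only one measured step exists, a 2.6-fold lower number from compound 1 to compound 2 (0.41 log units; beyond the scatter), which added a methyl at a different place, so it is a loose guide. That step added carbon and lowered the number, whereas here carbon leaves, so a modest rise in this assay is expected. The expected size is a 2.1-fold higher number from compound 1 to compound 3 (0.33 log units; beyond the scatter). The estimate for compound 3 is 30000 nM, with an expected range from 11000 nM to 80000 nM.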

Compound 3, half-maximal inhibitory concentration: 135000 nM
For compound 3 the middle estimate is 4.5-fold (0.65 log units) below the measured one; the measured number lies above the stated range.
By their numbers in this assay, from the lowest: compound 2; then compound 1; then compound 3.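

In this assay, putting hydrogen in place of ethyl on the saturated chain carbon bound to an amide-type nitrogen, which turns propyl into methyl, gives a 9.6-fold higher number from compound 1 to compound 3 (0.98 log units; beyond the scatter). The chain on this nitrogen therefore matters to the inhibition, and the earlier pair, which differed elsewhere, could not show that. Nothing available explains why the shorter chain gives the weaker inhibitor.

From the compounds shown here alone, with only propyl and methyl at this position, ethyl, the length in between, remains open. So does whether a longer chain such as butyl, or a chain ending in an amine, would lower the number further.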